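A few compounds are considered here, and "the series" means these few. Any claim that something is new, unique, unknown or untested is made for them only; others in the source may bear on it.

Among the compounds with values here, compound 1, with the structure `COc1ccc(/C=C2/CN(C)/C(=N/c3ccc(C)cc3)S2)cc1`, is the only member of this small set for which a number, rather than a limit, has been obtained. In a functional assay on HCT-116 cells (Homo sapiens) for antiproliferative activity, read by MTT assay, with a stated time of 72 h (a higher number here means a weaker inhibitor, a lower number a stronger inhibitor), compound 1 gives 11100 nM. Compound 2, with the structure `C=C1CN/C(=N/c2ccccc2)S1`, reaches only a limit of the assay, giving > 100000 nM in this assay. Compound 3, with the structure `COc1ccc(/C=C2\S/C(=N\c3ccc(C(C)(C)C)cc3)N(C)C2=O)cc1`, likewise reaches only a limit, giving > 100000 nM in this assay. So compound 1 stands alone with a measured value, while the other two sit at the limit of > 100000 nM in this assay, at which 2 of the 3 values shown sit.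

The step under consideration leads from compound 1 to compound 4, whose structure is `COc1ccc(/C=C2/CN(C)/C(=N/c3ccc(Cl)cc3)S2)cc1`. The difference between the two is chloro in place of methyl on an aromatic carbon, that is, a move from 4-methylphenyl to 4-chlorophenyl, with no change in ring count, in hydrogen-bond donors or acceptors, or in charge.

Within the data shown here, no step between two measured compounds is available to calibrate such a swap here, so the expectation rests on compound 1 alone. Compound 4 is expected to show a value of about 9000 nM in this assay, with a likely range from 3000 nM to 30000 nM. The corresponding step is expected to be a 1.2-fold lower number from compound 1 to compound 4 (0.09 log units; within the scatter), that is, a change no larger than the usual scatter, in no firm direction.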

Compound 4, half-maximal inhibitory concentration: 9800 nM
Compound 4: middle estimate off by 1.1-fold (0.04 log units), on the low side; the measured number falls inside the stated range.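

In this assay, within the data shown here, chloro in place of methyl on an aromatic carbon para to a large group gives a 1.1-fold lower number from compound 1 to compound 4 (0.05 log units; within the scatter), the first step in this set that can be read between two compounds differing in one place. It shows that, on the core of compound 1, the 4-methylphenyl and 4-chlorophenyl forms cannot be told apart in this read-out, so this one exchange at this position leaves the antiproliferative value where it was. Compounds 2 and 3 differ from compound 1 in more than one place, so no step to them can be read, and each stands at a limit of the assay: the limit of > 100000 nM in this assay, at which 2 of the 4 values shown sit.

On these data alone, only methyl and chloro have numbers at this position, so it remains open whether an amine, a carboxylic acid or a longer chain on the same aromatic carbon would shift the value beyond the scatter. As far as these compounds go, it is also open whether the same exchange would read alike on a different core, and whether the methoxy group on the other aromatic ring of compound 1 has any bearing on the value.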